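The source may hold more compounds than are shown below. What is called first, only, known or untested is meant among the compounds shown, and "the series" means these compounds.

In a functional assay on MCF-A cells (Homo sapiens) for cytotoxicity (on this read-out higher numbers stand for weaker inhibition of growth and lower numbers for stronger inhibition of growth), compound 1 (`CSc1ccc(C2=C(c3ccc(F)c(F)c3)C(=O)N3CCCC3C2)cc1`) gives 800 nM, and compound 2 (`CSc1ccc(C2=C(c3ccc(Br)cc3)C(=O)N3CCCC3C2)cc1`) gives 8000 nM. For the measured compounds named here, compound 2 therefore holds the higher of the two numbers so far, making it the weaker growth inhibitor of this pair. Compound 3 (`CSc1ccc(C2=C(c3ccc(C)cc3)C(=O)N3CCCC3C2)cc1`) keeps the shared core but has methyl in place of bromo on an aromatic carbon, turning 4-bromophenyl into 4-methylphenyl: methyl in place of bromo on an aromatic carbon. Going by the values given here, only one measured step bears on this change: a 10-fold higher number from compound 1 to compound 2 (1.00 log units; beyond the scatter). It shows that changing this phenyl group can shift the number beyond the scatter, but it involves no methyl group, so it is only a rough guide. Among the compounds with values here, since compound 2 stands at 8000 nM, the top of the numbers so far, a smaller move towards a lower number is expected in this assay. The expected change is a 2.7-fold lower number from compound 2 to compound 3 (0.43 log units; beyond the scatter). For compound 3, the estimated value is 3000 nM, within an expected range of 800 nM to 10000 nM.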

Compound 3, concentration for 50% growth inhibition: 600 nM
The estimate for compound 3 lay 5.0-fold (0.70 log units) above the measured number, outside the stated range (below it).
By their numbers in this assay, from the lowest: compounds 3 and 1 (each within the scatter of the next); then compound 2.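

Putting methyl in place of bromo on this aromatic carbon gives a 13-fold lower number from compound 2 to compound 3 (1.12 log units; beyond the scatter) in this assay, so a swap of one heavy atom for another at this place can move the number well beyond the scatter. The other new comparison, a 1.3-fold lower number from compound 1 to compound 3 (0.12 log units; within the scatter), shows that 4-methylphenyl and 3,4-difluorophenyl cannot be told apart on this read-out, which leaves compound 2, with its 4-bromophenyl group, as the weakest growth inhibitor of the three. Nothing available here accounts for the large gap between bromo and methyl.

On these data alone, with only these compounds, it remains open whether the low number seen with methyl is specific to that group. An amine, a methoxy group or a longer chain such as ethyl on the same aromatic carbon could fall on either side of it.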